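Morpholine to dimethylamino swap carried onto a second core

The source may report more compounds than this note shows. Statements on the series, on what has been measured and on what is new or still open speak of the compounds shown alone.

Compound 1 `CCC(CC)[C@@H]1C(=O)N[C@H](C2Cc3ccccc3C2)C(=O)N1[C@@H](C(=O)N1CCOCC1)c1ccc(C)nc1` and compound 2 `CCC(CC)[C@@H]1C(=O)N[C@H](C2Cc3ccccc3C2)C(=O)N1[C@@H](C(=O)N(C)C)c1ccc(C)nc1` share one core and differ only in dimethylamino in place of morpholin-4-yl on a carbonyl carbon. In an in vivo ADME assay on the whole organism for pharmacokinetics, with Rattus norvegicus as the target, at a dose of 5 mg/kg (on this read-out lower numbers stand for slow clearance and higher numbers for fast clearance), compound 1 gives 23 mL/min/kg, and in this assay compound 2 gives 20 mL/min/kg. The step between them, a 1.2-fold lower number from compound 1 to compound 2 (0.06 log units; within the scatter), is small and sits inside the usual scatter of repeated measurements.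

Compound 3 `COc1ccc([C@H](C(=O)N2CCOCC2)N2C(=O)[C@@H](C3Cc4ccccc4C3)NC(=O)[C@H]2CC(C)C)cn1` is built on another core; the difference between the two cores is not broken down here. In this assay compound 3 gives 35 mL/min/kg. Against compound 1 and compound 2 the gaps are within the scatter, so no order among the three measured compounds is drawn from these numbers.

Compound 4 `COc1ccc([C@H](C(=O)N(C)C)N2C(=O)[C@@H](C3Cc4ccccc4C3)NC(=O)[C@H]2CC(C)C)cn1` repeats the same change on the core of compound 3, namely (dimethylamino in place of morpholin-4-yl on a carbonyl carbon). The place of the change is described in the same words for both pairs, so this is the same change made in two pairs of compounds. What is expected for compound 4 rests on the earlier pair alone: the step from compound 1 to compound 2 was a 1.2-fold lower number from compound 1 to compound 2 (0.06 log units; within the scatter), and the step from compound 3 to compound 4 is estimated to be of the same small size, a 1.2-fold lower number from compound 3 to compound 4 (0.08 log units; within the scatter). On that basis compound 4 is expected to give about 29 mL/min/kg in this assay, with a plausible range from 17 mL/min/kg to 50 mL/min/kg.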

Compound 4, clearance in the Rattus norvegicus assay: 23 mL/min/kg
The estimate for compound 4 lay 1.3-fold (0.10 log units) above the measured number, within the range that was stated.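

In the Rattus norvegicus assay compound 3 gives 35 mL/min/kg and compound 4 gives 23 mL/min/kg, and the change from morpholin-4-yl to dimethylamino on a carbonyl carbon behaves alike on the two cores, the new step being a 1.5-fold lower number from compound 3 to compound 4 (0.18 log units; within the scatter) and the two steps not differing from each other: the same change on two cores in the Rattus norvegicus assay, a 1.2-fold lower number (0.06 log units; within the scatter) from compound 1 to compound 2 and a 1.5-fold lower number (0.18 log units; within the scatter) from compound 3 to compound 4, 1.3-fold (0.12 log units) apart, within the scatter of two such steps. What carries over is therefore only a step too small to tell from repeat measurements, so the two pairs show neither that the change truly moves clearance on either core nor that it would behave the same way on any core beyond these two. In a physicochemical assay for solubility, read by HPLC (a higher number here means a more soluble compound, a lower number a less soluble compound), compound 3 gives 249 ug/mL and compound 4 gives 216 ug/mL. For the compounds shown here, the one step available there, a 1.2-fold lower number from compound 3 to compound 4 (0.06 log units; within the scatter), is also within the scatter and rests on the core of compound 3 alone, so it gives no comparison between cores for solubility.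

The compounds shown cover only morpholin-4-yl and dimethylamino on this carbonyl carbon, so they leave open whether a step beyond the scatter would come from a different amine there, such as an azetidine, a piperidine or a piperazine. They also leave open whether a secondary amide carrying the amide hydrogen, or a longer chain on the nitrogen, would follow the same small step on both cores.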